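Adding a Dimethylamino Group to a Leukotriene Receptor Ligand

A few compounds are considered here, and "the series" means these few. Any claim that something is new, unique, unknown or untested is made for them only; others in the source may bear on it.

Compound 1, `COc1ccc(CCCCCCCCOc2ccc(C[S+]([O-])c3ccccc3)nc2/C=C/C(=O)O)cc1`: 37 nM
Compound 2, `CCCCCCCCCCCCOc1ccc(COc2cccc(C(=O)O)c2)nc1/C=C/C(=O)O`: 1130 nM

Of the compounds shown here, two have so far been measured in an assay for binding affinity to leukotriene B4 receptor 1 (Homo sapiens); on this read-out higher numbers stand for weaker inhibition and lower numbers for stronger inhibition. Of the two, compound 1 has the lower number, and compound 2 stands far above it, a gap well beyond the usual scatter of the assay. The two structures differ in many places at once, so that gap says nothing about any single change.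

Compound 3 `COc1ccc(CCCCCCCCOc2ccc(C[S+]([O-])c3cccc(N(C)C)c3)nc2/C=C/C(=O)O)cc1` has not yet been measured. It keeps the whole of compound 1 and alters one thing: dimethylamino in place of hydrogen on an aromatic carbon. Among the compounds with values here, no measured pair shows what a change of this kind does in this assay, so any expectation rests on compound 1 alone. Because compound 1 gives 37 nM in this assay, and the group that enters is small relative to the whole molecule, the step of a 1.1-fold higher number from compound 1 to compound 3 (0.03 log units; within the scatter) is expected to stay within the usual scatter, with no clear direction. Compound 3 is therefore estimated at 40 nM, with a range from 15 nM to 110 nM.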

Compound 3, inhibition constant: 245 nM
Compound 3: the middle estimate sits 6.1-fold (0.79 log units) below what was measured; the measured number lies above the stated range.
By their numbers in this assay, from the lowest: compound 1; then compound 3; then compound 2.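

In this assay, replacing phenyl with 3-(dimethylamino)phenyl gives a 6.6-fold higher number from compound 1 to compound 3 (0.82 log units; beyond the scatter). Within the data shown here, this is the first change in the set made at one place only, and it shows that this aromatic carbon is not indifferent to substitution: with the rest of compound 1 unchanged, dimethylamino on this ring alone is enough to move the number beyond the usual scatter, towards weaker inhibition. The loss is partial, as compound 3 still gives 245 nM, but the data shown offer no measured property that would explain the step.

Going by these compounds, what remains open is whether this step belongs to dimethylamino itself or would follow any group placed here, a question that a methyl group, a methoxy group, a fluorine atom or a primary amine at the same carbon could help to answer. It is also unknown whether dimethylamino on another carbon of this ring would give a similar step, since a single substitution at a single place cannot show how the rest of the ring responds.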